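The source may report more compounds than this note shows. Statements on the series, on what has been measured and on what is new or still open speak of the compounds shown alone.

Of the compounds shown here, three sharing one core have so far been measured in an assay on isolated protein for antagonist activity at transient receptor potential cation channel subfamily V member 1 (Homo sapiens); on this read-out lower numbers stand for stronger inhibition and higher numbers for weaker inhibition. Compound 1 `O=C(Nc1cccc(Br)c1)N1CCN(c2ccnc(Cl)n2)CC1` gives 1450 nM, compound 2 `O=C(Nc1cccc(F)c1)N1CCN(c2ccnc(Cl)n2)CC1` gives 952 nM, and compound 3 `O=C(Nc1cccc(C(F)(F)F)c1)N1CCN(c2ccnc(Cl)n2)CC1` gives 543 nM. Compound 2 thus holds the second highest of the three numbers, with compound 1 nearest to it. The measured steps are a 1.5-fold lower number from compound 1 to compound 2 (0.18 log units; within the scatter), a 1.8-fold lower number from compound 2 to compound 3 (0.24 log units; within the scatter) and a 2.7-fold lower number from compound 1 to compound 3 (0.43 log units; beyond the scatter). Compound 4 `O=C(Nc1ccc(Cl)cc1)N1CCN(c2ccnc(Cl)n2)CC1` has not been measured; it differs from compound 2 by 4-chlorophenyl in place of 3-fluorophenyl on an amide-type nitrogen. Among the compounds with values here, none of the measured steps covers this change, since each of them exchanges one group for another in the same place, and all of them moved the number only a little. The step from compound 2 to compound 4 is therefore expected to be a 1.1-fold higher number from compound 2 to compound 4 (0.02 log units; within the scatter), within the scatter. Compound 4 is expected to give 1000 nM, between 400 nM and 2500 nM.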

Compound 4, half-maximal inhibitory concentration: 1250 nM
Compound 4: the middle estimate sits 1.3-fold (0.10 log units) below what was measured; the measured number falls inside the stated range.
By their numbers in this assay, from the lowest: compounds 3, 2, 4 and 1 (each within the scatter of the next, the first and the last beyond it).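

Exchanging the 3-substituted ring on the amide-type nitrogen for 4-chlorophenyl gives a 1.3-fold higher number from compound 2 to compound 4 (0.12 log units; within the scatter) and a 1.2-fold lower number from compound 1 to compound 4 (0.06 log units; within the scatter). The earlier compounds shown here varied only the group on the ring, keeping its place fixed, whereas these steps change both the halogen and its place on the ring, and neither step leaves the scatter. No available evidence explains why these steps are so small.

A 3-chlorophenyl compound would be needed to separate the effect of the halogen from that of its place. On these data alone, how an amine or a carboxylic acid on this ring would behave also remains open.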